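The source may hold more compounds than are shown below. What is called first, only, known or untested is meant among the compounds shown, and "the series" means these compounds.

Measured in a functional assay on K562 cells (Homo sapiens) for cytotoxicity, read by MTT assay, with a stated time of 72 h; a lower number here means a stronger inhibitor of growth, a higher number a weaker inhibitor of growth:
- compound 1 `CS/C(=N\C(=O)c1ccco1)NC(=O)c1ccco1` gives 64800 nM
- compound 2 `O=C(/N=C(/NC(=O)c1cccs1)[Se]Cc1ccccc1)c1cccs1` gives 29500 nM
- compound 3 `CS/C(=N\C(=O)c1cccs1)NC(=O)c1cccs1` gives 72600 nM

Compound 1 and compound 3 differ in their cores; that difference is not broken down here, and their two values lie within the scatter of each other. Within the core of compound 3, one change is measured: a group of 8 heavy atoms (7 carbon, 1 selenium; one six-membered aromatic ring of carbon only) in place of a group of 2 heavy atoms (1 carbon, 1 sulfur; no ring), on a carbon with a double bond to nitrogen. This change gives a 2.5-fold lower number from compound 3 to compound 2 (0.39 log units; beyond the scatter).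

Compound 4 `O=C(/N=C(/NC(=O)c1ccco1)[Se]Cc1ccccc1)c1ccco1` is not yet measured in this assay. It carries the same change on the core of compound 1: a group of 8 heavy atoms (7 carbon, 1 selenium; one six-membered aromatic ring of carbon only) in place of a group of 2 heavy atoms (1 carbon, 1 sulfur; no ring), on a carbon with a double bond to nitrogen. Among the measured compounds shown here, only the one measured step supports the expectation, so the estimate rests on compound 3 and compound 2 alone, with a 2.5-fold lower number from compound 3 to compound 2 (0.39 log units; beyond the scatter) as its basis. Compound 4 is expected to show a 2.5-fold lower number from compound 1 to compound 4 (0.40 log units; beyond the scatter). Compound 4 is thus estimated at 26000 nM, with a range from 12000 nM to 56000 nM.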

Compound 4, concentration for 50% growth inhibition: 9530 nM
Beside the measured number, compound 4's estimate is 2.7-fold (0.44 log units) above it, outside the stated range (below it).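

The change from methylsulfanyl to the selenium-bearing group with its six-membered aromatic ring lowers the number on the core of compound 1 as well, with a 6.8-fold lower number from compound 1 to compound 4 (0.83 log units; beyond the scatter). In this assay the direction carries over between the two cores, but the size does not: the same change on two cores in this assay, a 2.5-fold lower number (0.39 log units; beyond the scatter) from compound 3 to compound 2 and a 6.8-fold lower number (0.83 log units; beyond the scatter) from compound 1 to compound 4, 2.8-fold (0.44 log units) apart, beyond the scatter of two such steps. Two cores set no rule for a third, and because selenium and the aromatic ring enter together, these steps do not separate their contributions.

The compounds shown leave open what methylselanyl or benzylsulfanyl would give on the carbon with a double bond to nitrogen, either of which would take these two parts apart. On these data alone, an amine at that place also remains open.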